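The compounds below may be only part of what the source reports. "The series", "measured", "known", "first", "only" and "open" are said of these compounds alone.

Working notes on the series. In a toxicity assay on MT4 cells (Homo sapiens) for cytotoxicity, read by MTT assay, with a stated time of 5 days (on this read-out lower numbers stand for higher toxicity in this test and higher numbers for lower toxicity in this test), compound 1 `Cc1cc(-c2cc(C)c(Nc3ccnc(Nc4ccc(C#N)cc4)n3)c(C)c2)ccn1` gives 4900 nM and compound 2 `Cc1cc(-c2ccnc(F)c2)cc(C)c1Nc1ccnc(Nc2ccc(C#N)cc2)n1` gives 6000 nM, so the two stand level. Compound 3 `Cc1cc(-c2cnc(C#N)nc2)cc(C)c1Nc1ccnc(Nc2ccc(C#N)cc2)n1` has 2-cyanopyrimidin-5-yl in place of 2-fluoropyridin-4-yl on an aromatic carbon. Among the measured compounds shown here, one measured step bears on this, and only loosely: a 1.2-fold higher number from compound 1 to compound 2 (0.09 log units; within the scatter), fluoro in place of methyl on an aromatic carbon. For the measured compounds named here, no measured compound carries 2-cyanopyrimidin-5-yl. On that thin basis, no step beyond the scatter is expected in this assay: the expected step is no change at the digits printed from compound 2 to compound 3 (within the scatter). For compound 3 the estimate is 6000 nM, with an expected range of 2000 nM to 20000 nM.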

Compound 3, half-maximal cytotoxic concentration: 3100 nM
Estimate against measurement, compound 3: 1.9-fold (0.29 log units) above; low and high end bracket the measured number.
By their numbers in this assay, from the lowest: compounds 3, 1 and 2 (each within the scatter of the next).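

Up to now, only the substituent on a pyridine ring had changed at this position, para to a large group; here the ring itself changes. In this assay 2-cyanopyrimidin-5-yl gives a 1.9-fold lower number from compound 2 to compound 3 (0.29 log units; within the scatter) and a 1.6-fold lower number from compound 1 to compound 3 (0.20 log units; within the scatter) and so stands level with both pyridines, even with a nitrile and an added ring nitrogen. No measured evidence bears on the reason. Still open, on these data alone, is whether a group without an aromatic ring here, such as an amine or a carboxylic acid, would move the number beyond the scatter in this assay.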